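The source may report more compounds than this note shows. Statements on the series, on what has been measured and on what is new or still open speak of the compounds shown alone.

Of the compounds shown here, three have been measured in a toxicity assay on MT4 cells (Homo sapiens) for cytotoxicity, read by MTT assay, with a stated time of 5 days; a higher number here means that more compound is tolerated, a lower number that less compound is tolerated. Compound 1, `Cc1cc(-c2ccc(C#N)cc2)cc(C)c1Oc1nc(Nc2ccc(C#N)c(F)c2)nc2ccsc12`, gives 71500 nM. Compound 2, `Cc1cc(-c2ccc(C#N)cc2)cc(C)c1Oc1nc(Nc2ccc(C#N)nc2)nc2ccsc12`, gives 214000 nM in this assay. Compound 3, `Cc1cc(/C=C/C#N)cc(C)c1Oc1nc(Nc2ccc(C#N)c(F)c2)nc2cc[nH]c12`, gives 188000 nM in this assay. The difference between the core of compound 1 and the core of compound 3 is not broken down here; their values show compound 3 at a higher number than compound 1, while compound 3 and compound 2 lie within the scatter of each other.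

From compound 1 to compound 2 the change is 6-cyanopyridin-3-yl in place of 4-cyano-3-fluorophenyl on a nitrogen on an aromatic ring, and this assay shows a 3.0-fold higher number from compound 1 to compound 2 (0.48 log units; beyond the scatter).

Compound 4, `Cc1cc(/C=C/C#N)cc(C)c1Oc1nc(Nc2ccc(C#N)nc2)nc2cc[nH]c12`, is not yet measured. It differs from compound 3 by 6-cyanopyridin-3-yl in place of 4-cyano-3-fluorophenyl on a nitrogen on an aromatic ring, the same change made from compound 1 to compound 2, at a place described in the same words. In this assay the step from compound 3 to compound 4 is expected to be a 2.4-fold higher number from compound 3 to compound 4 (0.38 log units; beyond the scatter), beside the earlier step of a 3.0-fold higher number from compound 1 to compound 2 (0.48 log units; beyond the scatter). This expectation rests on that single measured pair, so it is loose. The starting point of compound 3 at 188000 nM already lies high, so the number for compound 4 may run toward the top of what this assay reports. Compound 4 is expected to give about 450000 nM in this assay, with a range from 200000 nM to 1000000 nM.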

Compound 4, half-maximal cytotoxic concentration: 7940 nM
Estimate against measurement, compound 4: 57-fold (1.75 log units) above; measured number outside the range, below it.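

In this assay, 6-cyanopyridin-3-yl in place of 4-cyano-3-fluorophenyl gives a 24-fold lower number from compound 3 to compound 4 (1.37 log units; beyond the scatter), so the change does not carry over from one core to the other in either direction or size: the same change on two cores in this assay, a 3.0-fold higher number (0.48 log units; beyond the scatter) from compound 1 to compound 2 and a 24-fold lower number (1.37 log units; beyond the scatter) from compound 3 to compound 4, 71-fold (1.85 log units) apart, beyond the scatter of two such steps

A step measured on the core of compound 1 is therefore no usable guide to the same change on the core of compound 3, and the reverse holds as well. Within the data shown here, with only one measured pair on each core, the data do not show which feature of the two cores goes with the reversal, nor which step, if either, would be closer to the outcome on a third core.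

Still open, going by these compounds, is how the same change behaves on cores that differ from one another in one place only, which would separate the contributions of the ring system and the group carried on the dimethyl-substituted ring. Also open, on these data alone, is whether a pair bearing an amine or a carboxylic acid in place of the cyanovinyl group of compound 3 would follow the step seen on the core of compound 1 or the one seen on the core of compound 3.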